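The source may report more compounds than this note shows. Statements on the series, on what has been measured and on what is new or still open speak of the compounds shown alone.

The series shares the core of compound 1 `Cc1[nH]nc(N)c1-c1ccc(Cl)c(Cl)c1`. In an assay on Sf9 cells for inhibition of mitogen-activated protein kinase kinase kinase 14 (Homo sapiens), read by ADP-Glo, with a stated time of 60 min (on this read-out higher numbers stand for weaker inhibition and lower numbers for stronger inhibition), compound 1 gives > 100000 nM, which is a limit of the assay and not a number. Compound 2 `Cc1[nH]nc(N)c1-c1cccc(Cl)c1` gives > 100000 nM in this assay, again a limit. Compound 3 `Cc1c(-c2ccc(Cl)c(Cl)c2)c(N)nn1C` gives > 100000 nM in this assay, also a limit. All three values sit at the limit of > 100000 nM in this assay, at which 3 of the 3 values shown sit, so the steps a step that the two limits leave unreadable from compound 1 to compound 2 and a step that the two limits leave unreadable from compound 1 to compound 3 have no readable size. Compound 4 `Cc1[nH]nc(NC(=O)C(F)(F)F)c1-c1ccc(Cl)c(Cl)c1` differs from compound 1 by (trifluoromethyl)carbonyl in place of hydrogen on a nitrogen on an aromatic ring. Going by the values given here, no measured step touches that nitrogen, and the measured steps give no size to lean on. Compound 4 is therefore expected to give about 100000 nM in this assay, estimated between 20000 nM and 500000 nM. The step of a number no higher from compound 1 to compound 4 (the limit leaves the size open) is the one this estimate expects.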

Compound 4, half-maximal inhibitory concentration: > 100000 nM
Compound 4 was reported as a limit; the forecaster's own chance of this, stated with the estimate: 75%; the middle value lies on the limit itself.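

The step between compound 1 and compound 4 cannot be read, as both values are limits of the assay and not numbers: the limit of > 100000 nM in this assay, at which 4 of the 4 values shown sit.

The compounds shown leave open which change to the shared core, if any, would give a readable value.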